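This account rests on a few compounds, and the source may have more. Where it says the series, first, only, none or still open, it means among the compounds named here.

Working notes on the series. In a functional assay on Bel7402/5-FU cells (Homo sapiens) for cytotoxicity, read by MTT assay, with a stated time of 72 h (on this read-out higher numbers stand for weaker inhibition and lower numbers for stronger inhibition), compound 1 `O=C1C=CCC/C1=C\C=C\c1ccccc1` gives 4200 nM and compound 2 `CC(=C\c1ccccc1)/C=C1\CCC=CC1=O` gives 4200 nM as well, so compound 2 stands level with compound 1. Next comes compound 3 `O=C1C=CCC/C1=C\C(Br)=C\c1ccccc1`, reached from compound 2 by the change bromo in place of methyl on a double-bonded chain carbon bound to two double-bonded chain carbons in which bromo takes the place of methyl on a double-bonded chain carbon bound to two double-bonded chain carbons. Among the measured compounds shown here, one measured step bears on this place: no change at the digits printed from compound 1 to compound 2 (within the scatter) for methyl in place of hydrogen, which lies within the scatter. For the measured compounds named here, no bromo compound has been measured, so that single step guides the expectation only loosely and the range stays wide. No shift beyond the scatter is expected in this assay and no direction is favoured. The estimated step is a 1.2-fold lower number from compound 2 to compound 3 (0.08 log units; within the scatter) for this change. Compound 3 is estimated at 3500 nM with 1300 nM to 9000 nM as its expected range.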

Compound 3, half-maximal inhibitory concentration: > 10000 nM
Compound 3: only a limit was reported; the forecaster's own chance of this, stated with the estimate: 2%; middle value at least 2.8-fold (0.45 log units) from the limit.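

Up to compound 2 this place showed no sensitivity in this assay, with no change at the digits printed from compound 1 to compound 2 (within the scatter). Bromo changes that, with an at least 2.3-fold higher number from compound 2 to compound 3 (0.37 log units; beyond the scatter) and an at least 2.3-fold higher number from compound 1 to compound 3 (0.37 log units; beyond the scatter), so the double-bonded chain carbon bound to two double-bonded chain carbons does respond to the group it carries, and weaker inhibition follows here from bromo but not from methyl. The reading for compound 3 is a limit and not a number, so both steps give only their smallest size: the limit of > 10000 nM in this assay, at which 1 of the 3 values shown sits.

On these data alone, how far compound 3 really lies from compound 1 and compound 2 stays open. So does whether the weakening belongs to bromo alone or also appears with chloro, fluoro, methoxy or a longer chain such as ethyl at this place.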